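Exchanging the amide substituent on a shared core

The compounds below may be only part of what the source reports. "The series", "measured", "known", "first", "only" and "open" are said of these compounds alone.

Measured compounds:
compound 1 `CCC(=O)Nc1c(C(O)(C(F)(F)F)C(F)(F)F)ccc2ccccc12` — 96%
compound 2 `CC(C)=CC(=O)Nc1c(C(O)(C(F)(F)F)C(F)(F)F)ccc2ccccc12` — 96%

In a functional assay (Sus scrofa) with sulfonylurea receptors; K-ATP channels (Homo sapiens) as the target (a lower number here means a smaller maximal response, a higher number a larger maximal response), compound 1 gives 96% and compound 2 gives 96%. Compound 1 thus stands level with compound 2 at the digits shown. Compound 3 `O=C(Nc1c(C(O)(C(F)(F)F)C(F)(F)F)ccc2ccccc12)c1ccco1` differs from compound 1 by furan-2-yl in place of ethyl on a carbonyl carbon. For the measured compounds named here, the one measured step, no change at the digits printed from compound 1 to compound 2 (within the scatter), also exchanged the group on the carbonyl carbon and stayed within the scatter, so a similar outcome is expected here, although the entering group is now a ring. Compound 3 is therefore expected to show a number 4 percentage points lower from compound 1 to compound 3 (within the scatter) in this assay. The efficacy of compound 3 is estimated at 92%, within 78% to 102%.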

Compound 3, largest response reached (reported as efficacy), in percent of the reference or control that the assay uses: 96%
Compound 3: the middle estimate sits 4 percentage points below what was measured; the range from low to high includes it.
By their numbers in this assay, from the lowest: compounds 1, 2 and 3 (each within the scatter of the next).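

In this assay, for the compounds shown here, the earlier compounds had only open-chain groups on the carbonyl carbon, whereas furan-2-yl now brings a ring and a hydrogen-bond acceptor to this place. Replacing ethyl with it gives no change at the digits printed from compound 1 to compound 3 (within the scatter) and replacing 2-methylprop-1-en-1-yl with it gives no change at the digits printed from compound 2 to compound 3 (within the scatter) so this position accepts an aromatic ring here without a shift in maximal response. Nothing available explains this sameness. On these data alone, whether a longer chain, a carboxylic acid or an amine in this place would leave the response equally unchanged remains open.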